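The compounds below may be only part of what the source reports. "The series", "measured", "known", "first", "only" and "open" are said of these compounds alone.

Measured in a physicochemical assay for lipophilicity, read by HPLC, in phosphate buffer, measured as chromatographic lipophilicity, at pH 7.4; a lower number here means a more polar compound, a higher number a more lipophilic compound:
compound 1, `CCOc1ccc2nc(C)cc(OCC(=O)Nc3cc(C)cc(C)c3)c2c1`, 5.98
compound 2, `COc1ccc2nc(C(F)(F)F)cc(OCC(=O)Nc3cc(C)cc(C)c3)c2c1`, 7.02
compound 3, `COc1ccc(NC(=O)COc2cc(C)nc3ccc(OC)cc23)cc1`, 4.22

In this assay compound 3 stands lowest of the three numbers; compound 1 is nearest to it and compound 2 furthest, both higher by more than the usual scatter. Compound 4, `COc1ccc2nc(C)cc(OCC(=O)Nc3nccs3)c2c1`, is not yet measured. It differs from compound 3 in one place: 1,3-thiazol-2-yl in place of 4-methoxyphenyl on an amide-type nitrogen. The amide-type nitrogen and the carbonyl carbon stay as they are. For the measured compounds named here, no measured pair here shows this same change, so its size is uncertain. As the group that enters has fewer heavy atoms and more hydrogen-bond acceptors than the group that leaves, a step toward lower numbers, beyond the scatter, is expected: a number 0.82 log units lower from compound 3 to compound 4 (beyond the scatter) is the estimated step. Compound 4 is expected to give about 3.4, within a range from 2.6 to 4.2.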

Compound 4, distribution coefficient: 3.2
The estimate for compound 4 lay 0.20 log units above the measured number; the measured number falls inside the stated range.
By their numbers in this assay, from the lowest: compound 4; then compound 3; then compound 1; then compound 2.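

With 1,3-thiazol-2-yl in place of 4-methoxyphenyl on the amide-type nitrogen, this assay shows a number 1.02 log units lower from compound 3 to compound 4 (beyond the scatter). This is the first change in one place among these compounds, and it shows that the group at this position can, on its own, move the number by more than the scatter. Nothing available here accounts for the size of this step. On these data alone, it remains open whether plain phenyl or pyridin-2-yl on this nitrogen would give a similar step, and so whether the smaller group or its hetero atoms matter more.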